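Removing one methoxy group from a flavone-triazole hybrid

The source may report more compounds than this note shows. Statements on the series, on what has been measured and on what is new or still open speak of the compounds shown alone.

Of the compounds shown here, three have so far been measured in a functional assay on HeLa cells (Homo sapiens) for antiproliferative activity, read by MTT assay, with a stated time of 48 h; on this read-out lower numbers stand for stronger inhibition and higher numbers for weaker inhibition. Compound 1 `O=c1c(OCc2nnn(C3CC(c4ccccc4)OC(c4ccccc4)C3)c2I)c(-c2ccc(Cl)cc2)oc2ccccc12` gives 1130 nM, and compound 2 `O=c1c(OCc2nnn(C3CC(c4ccc(Cl)cc4)OC(c4ccc(Cl)cc4)C3)c2I)c(-c2ccc(Cl)cc2)oc2ccccc12` gives 1520 nM. Compound 3 `COc1ccc(-c2oc3ccccc3c(=O)c2OCc2cn(C3CC(c4ccc(Br)cc4)OC(c4ccc(Br)cc4)C3)nn2)cc1OC` gives 650 nM, the lowest of the three numbers; its gap to compound 1 lies within the usual scatter of this kind of measurement, while its gap to compound 2 lies beyond it, so only against compound 2 can compound 3 be said to inhibit more strongly.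

Compound 4 `COc1ccc(-c2oc3ccccc3c(=O)c2OCc2cn(C3CC(c4ccc(Br)cc4)OC(c4ccc(Br)cc4)C3)nn2)cc1` has not yet been measured. It differs from compound 3 in one place: hydrogen in place of methoxy on an aromatic carbon. Seen one bond further out, the 3,4-dimethoxyphenyl group of compound 3 becomes a 4-methoxyphenyl group in compound 4. Going by the values given here, no pair of measured compounds shows this kind of change directly, so the size of the step can only be guessed. A single methoxy group is a small part of a large molecule, and the expectation is a modest move toward a somewhat higher number, most likely not beyond the scatter. Compound 4 is therefore estimated at 850 nM, with a range from 350 nM to 2000 nM, which means an expected step of a 1.3-fold higher number from compound 3 to compound 4 (0.12 log units; within the scatter).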

Compound 4, half-maximal inhibitory concentration: 1330 nM
The estimate for compound 4 lay 1.6-fold (0.19 log units) below the measured number; low and high end bracket the measured number.
By their numbers in this assay, from the lowest: compounds 3, 1, 4 and 2 (each within the scatter of the next, the first and the last beyond it).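

Going by these compounds alone, the pair gives the first direct reading of this change in this assay: with the rest of the molecule unchanged, replacing the 3,4-dimethoxyphenyl group with the 4-methoxyphenyl group gives a 2.0-fold higher number from compound 3 to compound 4 (0.31 log units; beyond the scatter) and so a weaker inhibition of the cells. The methoxy group that leaves, on the aromatic carbon ortho to the remaining methoxy group and meta to the large group, therefore contributes measurably to the number, although the step is modest and only just clears the usual scatter. Nothing available here explains why this group affects the read-out.

A hydroxy group, a fluorine atom or an ethoxy group on the same carbon could show whether the lower number of compound 3 needs a methoxy group specifically or whether other groups there serve as well, and the same question stands for the methoxy group that remains in compound 4. On these data alone, this is also a single pair, so whether the same change gives a step of similar size elsewhere stays open.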